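Replacing the nitro-bearing ring of compound 1 with a difluorophenyl

The source may hold more compounds than are shown below. What is called first, only, known or untested is meant among the compounds shown, and "the series" means these compounds.

Measured so far:
- compound 1, `COc1ccc2[nH]c3c(c2c1)CCNC31CCN(Cc2ccc([N+](=O)[O-])cc2F)CC1`: 5900 nM
- compound 2, `COc1ccc2[nH]c3c(c2c1)CCNC31CCN(Cc2c(F)ccc(Cl)c2F)CC1`: 1500 nM
- compound 3, `COc1ccc2[nH]c3c(c2c1)CCNC31CCN(Cc2ccc(Br)cc2F)CC1`: 1600 nM

All three share the same core and differ only in the aromatic ring attached to a saturated chain carbon bound to an amine nitrogen in a ring. In an assay on FRT cells for positive allosteric modulation of Cystic fibrosis transmembrane conductance regulator variant N1303K (Homo sapiens), in the presence of a further agent that is not named here (on this read-out lower numbers stand for an effect already at smaller amounts and higher numbers for an effect only at larger amounts of compound), compound 1 gives the highest of the three numbers. The step of a 3.9-fold lower number from compound 1 to compound 2 (0.59 log units; beyond the scatter) and the step of a 3.7-fold lower number from compound 1 to compound 3 (0.57 log units; beyond the scatter) are both beyond the scatter, so both halogenated rings give an effect at smaller amounts than the nitro-bearing ring of compound 1. Compound 2 and compound 3 lie within the scatter of each other, as a 1.1-fold higher number from compound 2 to compound 3 (0.03 log units; within the scatter) shows.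

Compound 4, `COc1ccc2[nH]c3c(c2c1)CCNC31CCN(Cc2cc(F)cc(F)c2)CC1`, has not yet been measured. Its change from compound 1 is 3,5-difluorophenyl in place of 2-fluoro-4-nitrophenyl on a saturated chain carbon bound to an amine nitrogen in a ring. Like compound 2 and compound 3, it drops the nitro group and keeps only halogens on the ring, so the steps from compound 1 to compound 2 and from compound 1 to compound 3 are the ones that bear on it. Because a 3.9-fold lower number from compound 1 to compound 2 (0.59 log units; beyond the scatter) and a 3.7-fold lower number from compound 1 to compound 3 (0.57 log units; beyond the scatter) point the same way, a step of similar size and direction is expected, here a 3.0-fold lower number from compound 1 to compound 4 (0.47 log units; beyond the scatter). For compound 4 the estimate in this assay is 2000 nM, with a range from 800 nM to 5000 nM.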

Compound 4, half-maximal effective concentration: 11100 nM
Compound 4: the middle estimate sits 5.6-fold (0.74 log units) below what was measured, outside the stated range (above it).
By their numbers in this assay, from the lowest: compounds 2 and 3 (each within the scatter of the next); then compounds 1 and 4 (each within the scatter of the next).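

Removing the nitro group is not enough to shift the number in this assay, since the step is a 1.9-fold higher number from compound 1 to compound 4 (0.27 log units; within the scatter) and the 3,5-difluorophenyl ring cannot be told apart from the 2-fluoro-4-nitrophenyl ring. Rings carrying only halogens therefore do not behave as one family at this position, on a saturated chain carbon bound to an amine nitrogen in a ring: there is a 6.9-fold higher number from compound 3 to compound 4 (0.84 log units; beyond the scatter) and also a 7.4-fold higher number from compound 2 to compound 4 (0.87 log units; beyond the scatter), both clear separations even though all three rings lack the nitro group, so the identity and arrangement of the halogens count here, not merely their presence. Nothing measured here explains this separation.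

The compounds shown leave open which feature sets compound 2 and compound 3 apart from compound 4, as the rings of the first two differ from the 3,5-difluorophenyl ring in both the kind of halogen and where the halogens stand. Also open, going by these compounds, is how a nitrile, a methoxy group or a trifluoromethyl group would compare with the bromo group of compound 3 on the same aromatic carbon.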